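Three Limit-Only Thiosemicarbazones and a Nitrile Variant

The source may hold more compounds than are shown below. What is called first, only, known or untested is meant among the compounds shown, and "the series" means these compounds.

Compound 3 `Cc1cccc(NC(=S)N/N=C/c2ccc3ccccc3n2)c1` was tested in a functional assay on HT-29 cells (Homo sapiens) for antiproliferative activity, read by sulforhodamine B assay, with a stated time of 72 h; a higher number here means a weaker inhibitor, a lower number a stronger inhibitor. There compound 3 gives only a limit, > 100000 nM. Compound 1 `COc1ccccc1NC(=S)N/N=C/c1ccc2ccccc2n1` likewise gives a limit, > 100000 nM. Compound 2 `Fc1ccccc1NC(=S)N/N=C/c1ccc2ccccc2n1` also gives a limit, > 100000 nM. All three values sit at the limit of > 100000 nM in this assay, at which 3 of the 3 values shown sit. The steps a step that the two limits leave unreadable from compound 1 to compound 2, a step that the two limits leave unreadable from compound 1 to compound 3 and a step that the two limits leave unreadable from compound 2 to compound 3 therefore cannot be read in size or direction. Compound 4 `N#Cc1ccc(NC(=S)N/N=C/c2ccc3ccccc3n2)cc1` differs from compound 3 by 4-cyanophenyl in place of 3-methylphenyl on an amide-type nitrogen. Within the data shown here, no measured step bears readably on this change, so the data give no size or direction to expect in this assay beyond the scatter. Compound 4 is expected to give about 150000 nM, in a range from 40000 nM to 500000 nM. The expected step is a step that the limit leaves unreadable from compound 3 to compound 4, most likely again only a limit.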

Compound 4, half-maximal inhibitory concentration: 15600 nM
Compound 4: the middle estimate sits 9.6-fold (0.98 log units) above what was measured; the whole stated range lies above it.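

Among these compounds, putting 4-cyanophenyl on the amide-type nitrogen yields the only measured number in this assay, with an at least 6.4-fold lower number from compound 3 to compound 4 (0.80 log units; beyond the scatter), an at least 6.4-fold lower number from compound 2 to compound 4 (0.80 log units; beyond the scatter) and an at least 6.4-fold lower number from compound 1 to compound 4 (0.80 log units; beyond the scatter). This shows that the read-out can respond to a change at this place, which the earlier compounds could not show because each gave only a limit: the limit of > 100000 nM in this assay, at which 3 of the 4 values shown sit.

The compounds shown do not separate the effect of the nitrile from that of where it stands on the phenyl ring. As far as these compounds go, how a 4-aminophenyl or 4-carboxyphenyl group on the same nitrogen would read also remains open.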